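A few compounds are considered here, and "the series" means these few. Any claim that something is new, unique, unknown or untested is made for them only; others in the source may bear on it.

Measured so far in a functional assay on HL-60 cells (Homo sapiens) for antiproliferative activity, read by MTT assay; a higher number here means a weaker inhibitor, a lower number a stronger inhibitor:
compound 1 `O[C@@H]1[C@@H](OCc2ccccc2)[C@H](OCc2ccccc2)[C@@H](COCc2ccccc2)O[C@@H]1CC1CCCCC1`, 17200 nM
compound 2 `O[C@@H]1[C@@H](OCc2ccccc2)[C@H](OCc2ccccc2)[C@@H](COCc2ccccc2)O[C@H]1CC1CCCCC1`, 4100 nM
compound 3 `c1ccc(COC[C@H]2O[C@@H]3C[C@@H]3[C@@H](OCc3ccccc3)[C@@H]2OCc2ccccc2)cc1`, 38500 nM

Compound 2 stands lowest of the three numbers in this assay: compound 1 sits nearest and compound 3 furthest, both beyond the scatter. Going by the values given here, the only single-point step among the measured compounds is a 4.2-fold lower number from compound 1 to compound 2 (0.62 log units; beyond the scatter), a modest change that rests on the fact that compounds 1 and 2 differ only in the configuration as drawn alone. Compound 3 differs from compound 2 in more than one place, so its value can only be set beside that of compound 2 without a step.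

Compound 4 `CCC[C@@H]1O[C@H](COCc2ccccc2)[C@@H](OCc2ccccc2)[C@H](OCc2ccccc2)[C@H]1O` is the next compound to consider. Relative to compound 2 the change is ethyl in place of cyclohexyl on a saturated chain carbon bound to a saturated ring carbon. Among the compounds with values here, no measured step bears on this kind of change: the one step in hand concerns configuration, not the size of the side chain, and no compound with a shorter chain has been measured. The expectation for a 2.0-fold higher number from compound 2 to compound 4 (0.29 log units; within the scatter) is therefore a step of no clear direction, more likely a modest rise than a fall, and possibly within the scatter. Compound 4 is accordingly estimated at 8000 nM, with a range from 2500 nM to 30000 nM.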

Compound 4, half-maximal inhibitory concentration: 11700 nM
Compound 4: the middle estimate sits 1.5-fold (0.17 log units) below what was measured; the range from low to high includes it.
By their numbers in this assay, from the lowest: compound 2; then compounds 4 and 1 (each within the scatter of the next); then compound 3.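

In this assay replacing cyclohexyl with ethyl on a saturated chain carbon bound to a saturated ring carbon gives a 2.9-fold higher number from compound 2 to compound 4 (0.46 log units; beyond the scatter) and so shows that this position responds to the side chain as well as to configuration. The step is modest and compound 4 still gives 11700 nM in this assay and so the six-membered ring of cyclohexyl is not required for a measurable read-out here. The data in hand give no cause for this step.

As far as these compounds go, whether the step follows from losing the ring or from shortening the side chain stays open, and a straight hexyl chain or an amine at the same place would bear on that. Also open, from the compounds shown here alone, is whether the configuration step from the cyclohexyl pair holds with ethyl.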